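A few compounds are considered here, and "the series" means these few. Any claim that something is new, unique, unknown or untested is made for them only; others in the source may bear on it.

Compound 1 `COc1ccc2[nH]cc(/C=C/C(=O)c3ccncc3)c2c1` is the starting point here. Among the compounds with values here, in a functional assay on U-251 cells (Homo sapiens) for inhibition, with stated times of 24 h and 48 h (on this read-out higher numbers stand for weaker inhibition of growth and lower numbers for stronger inhibition of growth), compound 1 gives 18600 nM, and of the two values shown it is the only one reported as a number. Compound 2 `COc1ccc2[nH]c(C(C)C)c(/C=C/C(=O)c3ccncc3)c2c1` carries an isopropyl in place of hydrogen on an aromatic carbon of the shared core. In this assay compound 2 gives > 20000 nM, which is a limit of the assay and not a number (the limit of > 20000 nM in this assay, at which 1 of the 2 values shown sits). The step of an at least 1.0-fold higher number from compound 1 to compound 2 (0.03 log units; that floor lies within the scatter) is therefore known only as a floor. Compound 3 `COc1ccc2[nH]c(CC(C)C)c(/C=C/C(=O)c3ccncc3)c2c1` differs from compound 1 by isobutyl in place of hydrogen on an aromatic carbon. Within the data shown here, the isopropyl step is the single measured change that bears on this, and it reached only the limit, so the step is expected to run toward weaker inhibition, estimated as a 1.4-fold higher number from compound 1 to compound 3 (0.15 log units; within the scatter) in this assay. Compound 3 is thus expected to give about 26000 nM in this assay, within a range from 12000 nM to 60000 nM, with a real chance that only a limit is reported.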

Compound 3, concentration for 50% growth inhibition: 16600 nM
Compound 3: middle estimate off by 1.6-fold (0.19 log units), on the high side; the range from low to high includes it.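

Within the data shown here, compound 3 gives the first real number for a group on this carbon, the one next to the ring nitrogen. In this assay, the isobutyl change amounts to a 1.1-fold lower number from compound 1 to compound 3 (0.05 log units; within the scatter), so a four-carbon branched chain can sit here with no readable difference from hydrogen, and the earlier drift toward weaker inhibition is not borne out for this group. Compound 2 stays a limit and not a number, so an at least 1.2-fold lower number from compound 2 to compound 3 (0.08 log units; that floor lies within the scatter) is known only as a floor and does not order isobutyl against isopropyl: the limit of > 20000 nM in this assay, at which 1 of the 3 values shown sits.

The compounds shown carry only hydrogen and branched alkyl groups at this position. As far as these compounds go, it stays open whether an amine, a carboxylic acid or a longer chain on this carbon would shift growth inhibition beyond the scatter, in either direction.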